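Stacking a methoxy onto an already weakened sulfonyl analogue

This account rests on a few compounds, and the source may have more. Where it says the series, first, only, none or still open, it means among the compounds named here.

The measured compounds, with their numbers in a functional assay on A549 cells (Homo sapiens) for cytotoxicity, read by MTT assay, with a stated time of 72 h; a lower number here means a stronger inhibitor, a higher number a weaker inhibitor:
compound 1 `COc1cc(Nc2nc3ccccc3nc2S(=O)(=O)c2ccccc2)cc(OC)c1` gives 70 nM
compound 2 `COc1cc(Nc2nc3ccccc3nc2S(=O)(=O)c2ccccc2)cc(OC)c1OC` gives 9660 nM
compound 3 `COc1cc(Nc2nc3ccccc3nc2S(=O)(=O)c2ccc(C)cc2)cc(OC)c1` gives 8060 nM

Compound 3 holds the second highest of the three numbers in this assay; its nearest neighbour is compound 2, whose number lies within the usual scatter of it, while compound 1 sits far below, the step being a 120-fold higher number from compound 1 to compound 3 (2.06 log units; beyond the scatter). Compound 4 `COc1cc(Nc2nc3ccccc3nc2S(=O)(=O)c2ccc(C)cc2)cc(OC)c1OC` is compound 3 with methoxy in place of hydrogen on an aromatic carbon. Among the measured compounds shown here, one measured step bears directly on this change: the same added methoxy, on the same ring, turned compound 1 into compound 2 with a 140-fold higher number from compound 1 to compound 2 (2.14 log units; beyond the scatter). The methyl that distinguishes compound 3 from compound 1 cost a similar amount, so compound 3 already starts from a high number. He therefore expects the methoxy to raise the number again, though the data cannot show whether two large penalties simply add on top of each other. He estimates a step of a 6.2-fold higher number from compound 3 to compound 4 (0.79 log units; beyond the scatter), and for compound 4 an expected value of 50000 nM, within a range from 10000 nM to 250000 nM.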

Compound 4, half-maximal inhibitory concentration: 5610 nM
Compound 4: middle estimate off by 8.9-fold (0.95 log units), on the high side; the whole stated range lies above it.
By their numbers in this assay, from the lowest: compound 1; then compounds 4, 3 and 2 (each within the scatter of the next).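

In this assay the added methoxy proves to depend on its core: where it raised the number steeply on compound 1, here it gives only a 1.4-fold lower number from compound 3 to compound 4 (0.16 log units; within the scatter), so the two large penalties do not add: the same change on two cores in this assay, a 140-fold higher number (2.14 log units; beyond the scatter) from compound 1 to compound 2 and a 1.4-fold lower number (0.16 log units; within the scatter) from compound 3 to compound 4, 200-fold (2.30 log units) apart, beyond the scatter of two such steps. The methyl, read from the other side, shows the same thing, giving a 1.7-fold lower number from compound 2 to compound 4 (0.24 log units; within the scatter) where it was costly on compound 1: the same change on two cores in this assay, a 120-fold higher number (2.06 log units; beyond the scatter) from compound 1 to compound 3 and a 1.7-fold lower number (0.24 log units; within the scatter) from compound 2 to compound 4, 200-fold (2.30 log units) apart, beyond the scatter of two such steps. Either change alone is enough to lift compound 1 to the level of the others, and the second change then moves nothing beyond the scatter.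

These compounds do not tell why the two changes fail to add. From the compounds shown here alone, it also remains open how a hydroxyl or an amine in place of that methoxy, or a chlorine or an ethyl in place of the methyl, would fare on the core of compound 1.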